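Chromone triazole ethers: HeLa cytotoxicity working notes

The source may report more compounds than this note shows. Statements on the series, on what has been measured and on what is new or still open speak of the compounds shown alone.

Measured so far:
- compound 1 `O=c1ccoc2cc(OCc3cn(Cc4ccccc4)nn3)ccc12`: in a functional assay on HeLa cells (Homo sapiens) for cytotoxicity, read by MTT assay, with a stated time of 48 h (a lower number here means a stronger inhibitor, a higher number a weaker inhibitor), compound 1 gives > 100000 nM, a limit of the assay rather than a number; it sits at the limit of > 100000 nM in this assay, at which 1 of the 3 values shown sits.
- compound 2 `O=c1ccoc2cc(OCc3cn(Cc4ccc(Cl)cc4Cl)nn3)ccc12`: compound 2 gives 80600 nM.
- compound 3 `C#CCOc1ccc2c(=O)ccoc2c1`: compound 3 gives 64700 nM.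

Compound 2 stands highest of the two numbers, and compound 3 lies within the scatter of it; the remaining value is the limit of compound 1.

Compound 4 `N#Cc1cccc(Cn2cc(COc3ccc4c(=O)ccoc4c3)nn2)c1` differs from compound 2 by 3-cyanophenyl in place of 2,4-dichlorophenyl on a saturated chain carbon bound to an aromatic nitrogen. Among the compounds with values here, the one step touching this place is an at least 1.2-fold lower number from compound 1 to compound 2 (0.09 log units; that floor lies within the scatter), a change that did not rise above the scatter. Within the data shown here, no other step bears on it.

Compound 4 is therefore expected to show a 1.1-fold higher number from compound 2 to compound 4 (0.05 log units; within the scatter), no step beyond the scatter. The estimate for compound 4 is 90000 nM, with a range from 40000 nM to 200000 nM.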

Compound 4, half-maximal inhibitory concentration: > 100000 nM
Compound 4: no number, only a limit; the forecaster's own chance of this, stated with the estimate: 40%; middle value at least 1.1-fold (0.04 log units) from the limit.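

Replacing 2,4-dichlorophenyl with 3-cyanophenyl at this place gives an at least 1.2-fold higher number from compound 2 to compound 4 (0.09 log units; that floor lies within the scatter) in this assay, so the true size of the change stays unresolved. Of the three groups shown here, only 2,4-dichlorophenyl gives a number, although both steps involving it have floors within the scatter. Compound 4 gives a limit of the assay rather than a number, and its step to compound 1 cannot be read: the limit of > 100000 nM in this assay, at which 2 of the 4 values shown sit.

Going by these compounds, how far compound 1 and compound 4 lie past the limit remains open. Also open, on these data alone, is whether an amine or a carboxylic acid on the phenyl ring, or a longer chain to it, would give a clearly lower number.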